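A Second Fluorine on the Fused Ring of Compound 2

A few compounds are considered here, and "the series" means these few. Any claim that something is new, unique, unknown or untested is made for them only; others in the source may bear on it.

Of the compounds shown here, two have been measured so far. Compound 1 `CC(C)C(/C=C1/CCNC1=O)c1ccc(-c2ccc3cccc(F)c3c2)[nH]c1=O` and compound 2 `CCC(CC)(c1nnc[nH]1)c1ccc(-c2ccc3cccc(F)c3c2)[nH]c1=O` share a core and differ in the group attached to it. In a functional assay on CHO cells for antagonist activity at prostaglandin E2 receptor EP3 subtype (Homo sapiens), read by cAMP accumulation (on this read-out lower numbers stand for stronger inhibition and higher numbers for weaker inhibition), compound 1 gives 8.1 nM, and compound 2 gives 36 nM. Compound 2 thus stands at the higher of the two numbers, the weaker inhibitor of the pair, and its distance from compound 1 lies beyond the usual scatter of repeated measurements.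

Compound 3 `CCC(CC)(c1nnc[nH]1)c1ccc(-c2ccc3cc(F)cc(F)c3c2)[nH]c1=O` has not been measured. It is compound 2 with a single change, (fluoro in place of hydrogen on an aromatic carbon), so that the fused two-ring system carries two fluoro groups instead of one. Going by the values given here, no measured pair shows what this change does. For compound 3 no step beyond the scatter is expected in this assay, in either direction. Compound 3 is therefore expected to give 30 nM, within a range from 10 nM to 90 nM. That estimate amounts to an expected step of a 1.2-fold lower number from compound 2 to compound 3 (0.08 log units; within the scatter).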

Compound 3, half-maximal inhibitory concentration: 350 nM
Compound 3: the middle estimate sits 12-fold (1.07 log units) below what was measured; measured number above the stated range.
By their numbers in this assay, from the lowest: compound 1; then compound 2; then compound 3.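

In this assay, fluoro in place of hydrogen on this aromatic carbon, meta to the fluoro group already on the fused two-ring system, gives a 9.7-fold higher number from compound 2 to compound 3 (0.99 log units; beyond the scatter). Adding one heavy atom at this position is therefore enough to weaken inhibition beyond the scatter, so the position is not a neutral place for fluoro, at least with the group that compound 2 carries on the shared core. No measurement available here accounts for this loss.

From the compounds shown here alone, it remains open whether the same fluoro would weaken inhibition as much with the group that compound 1 carries in place of that of compound 2. Also open, going by these compounds, is how a chlorine atom, a methoxy group or an amine would compare with fluoro at this position.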